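The source may report more compounds than this note shows. Statements on the series, on what has been measured and on what is new or still open speak of the compounds shown alone.

Compound 1 `COc1ccc2c(C3(c4c[nH]c5cc(OC)ccc45)C(=O)Nc4ccccc43)c[nH]c2c1` is one of two members of a shared core that have been measured in a functional assay on SK-N-SH cells (Homo sapiens) for cytotoxicity, read by MTT assay, with a stated time of 48 h; on this read-out lower numbers stand for stronger inhibition and higher numbers for weaker inhibition. In this assay compound 1 gives 13600 nM. Its companion, compound 2 `O=C1Nc2ccccc2C1(c1c[nH]c2ccc(Cl)cc12)c1c[nH]c2ccc(Cl)cc12`, gives 9400 nM in this assay, and the two numbers lie within the scatter of each other, so nothing separates them beyond the usual spread of repeated measurements.

Compound 3 `COc1ccc2c(C3(c4c[nH]c5cc(OC)ccc45)C(=O)Nc4ccc(F)cc43)c[nH]c2c1` has not yet been measured. It differs from compound 1 by a single change: fluoro in place of hydrogen on an aromatic carbon. Going by the values given here, no step between measured compounds shows what this kind of change does on the shared core, so any expectation rests on the two numbers alone. The step from compound 1 to compound 3 is expected to be small, with no direction that rises beyond the scatter, which is what a 1.2-fold lower number from compound 1 to compound 3 (0.09 log units; within the scatter) expresses. Compound 3 is therefore estimated to give 11000 nM in this assay, with a range from 4000 nM to 30000 nM.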

Compound 3, half-maximal inhibitory concentration: 4100 nM
Beside the measured number, compound 3's estimate is 2.7-fold (0.43 log units) above it, and the stated range covers the measured number.
By their numbers in this assay, from the lowest: compound 3; then compounds 2 and 1 (each within the scatter of the next).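

Fluoro in place of hydrogen, on an aromatic carbon meta to a fused ring and para to a fused ring, gives a 3.3-fold lower number from compound 1 to compound 3 (0.52 log units; beyond the scatter) in this assay. Going by these compounds alone, this is the first step on the shared core that can be read in one place, and it shows that this position responds to the entry of a single fluorine atom, something the two earlier compounds could not show. Nothing at hand bears on why the number falls.

On these data alone, whether trifluoromethyl, an amine or a carboxylic acid at the same position would move the number in the same direction remains open. Also open, as far as these compounds go, is whether fluoro at this position would bring a comparable step on the core of compound 2, which carries chloro in place of the methoxy groups of compound 1.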